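The source may hold more compounds than are shown below. What is called first, only, known or untested is meant among the compounds shown, and "the series" means these compounds.

Working notes on the series. Compound 1 `CC(C)(C)c1ccc(CCC(=S)NCc2ccc(NS(C)(=O)=O)c(Cl)c2)cc1` and compound 2 `CC(C)(C)c1ccc(CCC(=S)NCc2ccc(NS(C)(=O)=O)c(I)c2)cc1` share a core and differ only in the halogen on the aromatic ring that carries the methanesulfonamido group. In a functional assay for antagonist activity at transient receptor potential cation channel subfamily V member 1 (Rattus norvegicus) (a higher number here means a weaker inhibitor, a lower number a stronger inhibitor), compound 1 gives 96 nM and compound 2 gives 300 nM. For the measured compounds named here, the single measured step, a 3.1-fold higher number from compound 1 to compound 2 (0.49 log units; beyond the scatter), is the only comparison available, and it places compound 1 as the lowest of the two numbers so far.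

Compound 3 `Cc1cc(CNC(=S)CCc2ccc(C(C)(C)C)cc2)cc(Cl)c1NS(C)(=O)=O` keeps the chloro of compound 1 and changes it at one place: methyl in place of hydrogen on an aromatic carbon. Going by the values given here, no measured step in this assay touches that position or a methyl substituent at all; the step from compound 1 to compound 2 concerns the halogen and does not bear on an added methyl. With one heavy atom entering and the chloro and the rest of the core unchanged, the expectation rests on compound 1 alone, and the expected step of a 1.1-fold higher number from compound 1 to compound 3 (0.06 log units; within the scatter) is taken as one that stays within the usual scatter, with no direction asserted. Compound 3 is therefore expected to give about 110 nM in this assay, estimated to fall between 40 nM and 300 nM.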

Compound 3, half-maximal inhibitory concentration: 80 nM
Beside the measured number, compound 3's estimate is 1.4-fold (0.14 log units) above it; the range from low to high includes it.
By their numbers in this assay, from the lowest: compounds 3 and 1 (each within the scatter of the next); then compound 2.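

In this assay, methyl in place of hydrogen on the aromatic carbon ortho to a methanesulfonamido group and meta to a chloro group gives a 1.2-fold lower number from compound 1 to compound 3 (0.08 log units; within the scatter) and so leaves compound 3 and compound 1 indistinguishable in this read-out. This position therefore accepts one added carbon with the chloro in place, at least in the core of compound 1. The halogen change gives a different picture, with a 3.1-fold higher number from compound 1 to compound 2 (0.49 log units; beyond the scatter) as a step beyond the scatter, so among the changes shown so far, only the swap of chloro for iodo separates two compounds in this assay. No supporting measurement bears on this result, so the data give no explanation for it.

The compounds shown leave open whether this position would accept anything larger or of another kind than methyl, such as an ethyl group, a methoxy group or an amine. For the compounds shown here, they also leave open whether the methyl would give a similar result alongside the iodo of compound 2, since the added methyl has been seen only with the chloro.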